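A few compounds are considered here, and "the series" means these few. Any claim that something is new, unique, unknown or untested is made for them only; others in the source may bear on it.

Of the compounds shown here, three have been measured in a functional assay on HCT-116 cells (Homo sapiens) for inhibition, read by MTT assay, with a stated time of 72 h, tested at 20 uM (on this read-out lower numbers stand for less inhibition and higher numbers for more inhibition at the one concentration tested (going by the name of the read-out)), so far. Compound 1 `c1cc(N2CCCC2)nc(Nc2ccc(Oc3ncnc4ccsc34)cc2)n1` gives 22.2% in this assay. Compound 2 `CN(c1ccc(Oc2ncnc3ccsc23)cc1)c1nccc(N2CCc3ccccc3C2)n1` gives 58.3% in this assay. Compound 3 `CN(c1ccc(Oc2ncnc3sccc23)cc1)c1nccc(N2CCCC2)n1` gives 42.2% in this assay, which places it second highest of the three: compound 2 lies above it by a margin beyond the usual scatter, and compound 1 lies below it, also by a margin beyond the scatter.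

Compound 4 `CN(c1ccc(Oc2ncnc3ccsc23)cc1)c1nccc(N2CCCC2)n1` has not yet been measured. It is built from the same atoms as compound 3, joined differently: a group of 9 heavy atoms (6 carbon, 2 nitrogen, 1 sulfur; one five-membered aromatic ring with 1 hetero atom, one six-membered aromatic ring with 2 hetero atoms) in place of a group of 9 heavy atoms (6 carbon, 2 nitrogen, 1 sulfur; one five-membered aromatic ring with 1 hetero atom, one six-membered aromatic ring with 2 hetero atoms), on an oxygen on an aromatic ring. The two bicyclic groups share the same atom count, ring sizes and number of hydrogen-bond acceptors, so the change is a rearrangement within that group rather than an addition or removal. Compound 4 carries the same bicyclic group as compound 1 and compound 2, while keeping the rest of compound 3 unchanged. For the measured compounds named here, no pair of measured compounds differs in this one place alone, so there is no direct precedent for the size of the step.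

Given how little the group changes on paper, the step is expected to be small, with a number 2.8 percentage points higher from compound 3 to compound 4 (within the scatter) estimated as not beyond the scatter. Compound 4 is therefore expected to give about 45% in this assay, within a range from 30% to 60%.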

Compound 4, a percentage reported as inhibition, at one concentration (the size of the read-out at that concentration, not a potency): 63.6%
The estimate for compound 4 lay 18.6 percentage points below the measured number, outside the stated range (above it).
By their numbers in this assay, from the lowest: compound 1; then compound 3; then compounds 2 and 4 (each within the scatter of the next).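

Joining the same atoms differently within the bicyclic group on the oxygen is not a silent change: in this assay the rearrangement gives a number 21.4 percentage points higher from compound 3 to compound 4 (beyond the scatter), even though both groups have identical atom, ring and hydrogen-bond acceptor counts. With this group in place, the amine can differ without a clear effect, since pyrrolidin-1-yl in place of 1,2,3,4-tetrahydroisoquinolin-2-yl gives a number 5.3 percentage points higher from compound 2 to compound 4 (within the scatter), whereas methyl in place of hydrogen on the nitrogen gives a number 41.4 percentage points higher from compound 1 to compound 4 (beyond the scatter), the largest single-place step in this small set. The data offer no independent measurement that could explain any of these steps.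

Going by these compounds, it remains open whether the rearrangement would give a step of similar size in a compound with hydrogen on that nitrogen, or with 1,2,3,4-tetrahydroisoquinolin-2-yl in place of pyrrolidin-1-yl. On these data alone, it is also open how an ethyl group on the nitrogen or a morpholin-4-yl group in place of pyrrolidin-1-yl would read, and, with only one concentration tested, how these compounds differ in potency.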